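A few compounds are considered here, and "the series" means these few. Any claim that something is new, unique, unknown or untested is made for them only; others in the source may bear on it.

The series is built on one shared amide core that carries a phenyl substituent and a benzylated imidazole attached through a secondary amine. Compound 1 `CSCC[C@H](NC(=O)c1ccc(NCc2cncn2Cc2ccccc2C#N)cc1-c1ccccc1)C(=O)O` is the free acid. In a functional assay on NIH3T3 cells (Mus musculus) (on this read-out lower numbers stand for an effect already at smaller amounts and higher numbers for an effect only at larger amounts of compound), compound 1 reaches only the limit of the assay, > 10 uM. Compound 2 `N#Cc1ccc(Cn2cncc2CNc2ccc(C(=O)Nc3cccc([N+](=O)[O-])c3)c(-c3ccccc3)c2)cc1` is the nitro anilide. In this assay compound 2 likewise stops at a limit, > 10 uM. Compound 3 `COC(=O)[C@H](CCSC)NC(=O)c1ccc(NCc2cncn2Cc2cccc(C#N)c2)cc1-c1ccccc1` is the methyl ester. In this assay compound 3 also gives only a limit, > 10 uM. Among the measured compounds shown here, compound 3 therefore stands exactly where every measured member stands, at the limit of > 10 uM in this assay, at which 3 of the 3 values shown sit, and no numerical step between any two of them can be read off.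

Compound 4 `COC(=O)[C@H](CCSC)NC(=O)c1ccc(NCc2cncn2Cc2ccccc2C)cc1-c1ccccc1` has not yet been measured. It differs from compound 3 by 2-methylphenyl in place of 3-cyanophenyl on a saturated chain carbon bound to an aromatic nitrogen. For the measured compounds named here, the data hold no measured step that would size this change; compound 1 and compound 3, which differ only in their benzyl substituent, both sit at the limit, and nothing has yet entered the measurable range. In this assay compound 4 is expected to follow compound 3, with an estimated step that the limit leaves unreadable from compound 3 to compound 4 that amounts to none beyond the scatter. For compound 4 the estimate in this assay is 15 uM, expected to fall between 5 uM and 50 uM, most likely reported again only as a limit.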

Compound 4, concentration for half-maximal effect: > 10 uM
Compound 4: only a limit was reported (the forecaster's own chance of this, stated with the estimate: 80%); the middle value lies beyond the limit too.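

In this assay compound 4 again gives only a limit (> 10 uM). No step from compound 3 to compound 4 can be read, and every compound shown stands at the same place: the limit of > 10 uM in this assay, at which 4 of the 4 values shown sit. The compounds shown leave open what change to the shared core would bring a value into the measurable range of this assay.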